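This account rests on a few compounds, and the source may have more. Where it says the series, first, only, none or still open, it means among the compounds named here.

Within the data shown here, compound 1 `CN(C)CCNC(=O)Nc1cc2c(Nc3ccc(F)c(Cl)c3)ncnc2cc1O[C@H]1CCOC1` gives 806 nM in a functional assay on A-431 cells (Homo sapiens) for antiproliferative activity, read by sulforhodamine B assay, with a stated time of 72 h (a lower number here means a stronger inhibitor, a higher number a weaker inhibitor), the highest of the three numbers measured so far. Compound 2 `CCN(CC)CCN(C)C(=O)Nc1cc2c(Nc3ccc(F)c(Cl)c3)ncnc2cc1O[C@H]1CCOC1` gives 481 nM and compound 3 `CN(C)CCCN(C)C(=O)Nc1cc2c(Nc3ccc(F)c(Cl)c3)ncnc2cc1O[C@H]1CCOC1` gives 200 nM, with a 1.7-fold lower number from compound 1 to compound 2 (0.22 log units; within the scatter) and a 4.0-fold lower number from compound 1 to compound 3 (0.61 log units; beyond the scatter). Compound 4 `O=C(Nc1cc2c(Nc3ccc(F)c(Cl)c3)ncnc2cc1O[C@H]1CCOC1)N1CCC(CCO)CC1` is not yet measured; it differs from compound 1 in one place: 4-(2-hydroxyethyl)piperidin-1-yl in place of (2-(dimethylamino)ethyl)amino on a carbonyl carbon. Both measured steps from compound 1 changed the group on the same carbonyl carbon and both lowered the number, one within the scatter and one modestly beyond it, so a step of similar size, downward or none beyond the scatter, is expected here. For compound 4 the estimate is 500 nM, within 150 nM to 1600 nM, meaning a 1.6-fold lower number from compound 1 to compound 4 (0.21 log units; within the scatter).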

Compound 4, half-maximal inhibitory concentration: 759 nM
The estimate for compound 4 lay 1.5-fold (0.18 log units) below the measured number; low and high end bracket the measured number.
By their numbers in this assay, from the lowest: compound 3; then compounds 2, 4 and 1 (each within the scatter of the next).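

On the carbonyl carbon, 4-(2-hydroxyethyl)piperidin-1-yl, which brings a six-membered non-aromatic ring and drops the dimethylamino end, reads the same as (2-(dimethylamino)ethyl)amino in this assay (a 1.1-fold lower number from compound 1 to compound 4 (0.03 log units; within the scatter)). The ring group also stays within the scatter of (2-(diethylamino)ethyl)(methyl)amino (a 1.6-fold higher number from compound 2 to compound 4 (0.20 log units; within the scatter)), but not of (3-(dimethylamino)propyl)(methyl)amino (a 3.8-fold higher number from compound 3 to compound 4 (0.58 log units; beyond the scatter)), so compound 3 remains apart from the other three. No measurement on hand bears on the cause of these steps. From the compounds shown here alone, how a plain piperidin-1-yl or a 4-methylpiperazin-1-yl group would read on this carbonyl carbon stays open.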